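This account rests on a few compounds, and the source may have more. Where it says the series, first, only, none or still open, it means among the compounds named here.

Among the measured compounds shown here, in a toxicity assay on microsomes from liver (Mus musculus) for metabolic stability, read by LC-MS, using NADPH (a lower number here means slower removal, a higher number faster removal of the compound), compound 1 `C[C@@H]1CN(c2scnc2-c2nc3ccccc3[nH]2)CCN1C(=O)Cn1cnc2cccnc21` gives 0.028 mL/min/kg and compound 2 `C[C@@H]1CN(c2sc(C(F)(F)F)nc2-c2nc3ccccc3[nH]2)CCN1C(=O)Cn1cnc2cccnc21` gives 0.079 mL/min/kg, the higher of the two numbers measured so far. For the measured compounds named here, the only measured step, a 2.8-fold higher number from compound 1 to compound 2 (0.45 log units; beyond the scatter), is the exchange of hydrogen for trifluoromethyl on an aromatic carbon, and it lies modestly beyond the scatter. Compound 3 `CCOc1ncc(-c2nc(C(F)(F)F)sc2N2CCN(C(=O)Cn3cnc4cccnc43)[C@H](C)C2)cn1` keeps that trifluoromethyl group and differs from compound 2 elsewhere: 2-ethoxypyrimidin-5-yl in place of 1H-benzimidazol-2-yl on an aromatic carbon. Here 2-ethoxypyrimidin-5-yl stands in place of 1H-benzimidazol-2-yl on an aromatic carbon. Going by the values given here, no measured pair carries this exchange, so the step to compound 2 offers only a rough guide to size and none to direction. On that thin basis, a modest upward step is expected in this assay, although a result within the scatter of compound 2 would be quite possible. The estimated change is a 2.3-fold higher number from compound 2 to compound 3 (0.36 log units; beyond the scatter). The expected value for compound 3 is 0.18 mL/min/kg, with an estimated range from 0.05 mL/min/kg to 0.6 mL/min/kg.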

Compound 3, clearance: 0.042 mL/min/kg
Compound 3: middle estimate off by 4.3-fold (0.63 log units), on the high side; the whole stated range lies above it.
By their numbers in this assay, from the lowest: compounds 1, 3 and 2 (each within the scatter of the next, the first and the last beyond it).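

In this assay, the exchange of 1H-benzimidazol-2-yl for 2-ethoxypyrimidin-5-yl gives a 1.9-fold lower number from compound 2 to compound 3 (0.27 log units; within the scatter) and so shows that this aromatic carbon, next to the ring nitrogen, can carry either group without a step beyond the scatter. The two groups have the same heavy-atom count but differ in their rings and hydrogen-bonding counts: a five-membered aromatic ring and a six-membered aromatic ring of carbon only give way to one six-membered aromatic ring with 2 hetero atoms, and the hydrogen-bond donor count goes from 1 to 0. The compounds shown offer no evidence on why such different groups read alike here.

Among the compounds shown here, the exchange is seen only with trifluoromethyl on the core, so it remains open whether it would read the same with hydrogen in that place, as in compound 1. Also open, as far as these compounds go, is how much depends on the ethoxy part of the entering group, a question that a 2-methoxypyrimidin-5-yl or 2-aminopyrimidin-5-yl group at this position would address.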